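From a Piperidine Side Group to a Hydroxyethylamino Chain

This account rests on a few compounds, and the source may have more. Where it says the series, first, only, none or still open, it means among the compounds named here.

Three compounds sharing one core have numbers in a functional assay on LNCaP cells (Homo sapiens) for antiproliferative activity, read by MTT assay, with a stated time of 96 h; on this read-out higher numbers stand for weaker inhibition and lower numbers for stronger inhibition. Compound 1 (`FC(F)(F)Oc1cccc(Nc2nnnc3ccc(N4CCCC4)nc23)c1`) gives > 100000 nM, which is a limit of the assay and not a number. Compound 2 (`CC(C)N1CCN(c2ccc3nnnc(Nc4cccc(OC(F)(F)F)c4)c3n2)CC1`) gives 10700 nM, and compound 3 (`FC(F)(F)Oc1cccc(Nc2nnnc3ccc(N4CCC(N5CCCC5)CC4)nc23)c1`) gives 10700 nM. Among the measured compounds shown here, compound 3 therefore stands level with the only other compound that has a measured number, with no change at the digits printed from compound 2 to compound 3 (within the scatter). Against the pyrrolidin-1-yl of the first compound, 4-isopropylpiperazin-1-yl gave an at least 9.3-fold lower number from compound 1 to compound 2 (0.97 log units; beyond the scatter), and 4-(pyrrolidin-1-yl)piperidin-1-yl gave an at least 9.3-fold lower number from compound 1 to compound 3 (0.97 log units; beyond the scatter).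

Compound 4 (`OCCNc1ccc2nnnc(Nc3cccc(OC(F)(F)F)c3)c2n1`) carries (2-hydroxyethyl)amino in place of 4-(pyrrolidin-1-yl)piperidin-1-yl on an aromatic carbon, ((2-hydroxyethyl)amino in place of 4-(pyrrolidin-1-yl)piperidin-1-yl on an aromatic carbon). For the measured compounds named here, the steps out of compound 1 are the closest guide, since they are the only measured changes at this carbon that moved the number. Compound 4 gives up the same large group that produced an at least 9.3-fold lower number from compound 1 to compound 3 (0.97 log units; beyond the scatter), so part of that gain is expected to be lost, though the entering chain is not pyrrolidin-1-yl and the full loss is not assured. The expected change is a 3.3-fold higher number from compound 3 to compound 4 (0.51 log units; beyond the scatter), toward weaker inhibition. A result reported only as a limit remains possible, as with the limit of > 100000 nM in this assay, at which 1 of the 3 values shown sits. Compound 4 is estimated at 35000 nM, with an expected range from 10000 nM to 100000 nM.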

Compound 4, half-maximal inhibitory concentration: 42900 nM
Compound 4: the middle estimate sits 1.2-fold (0.09 log units) below what was measured, and the stated range covers the measured number.
By their numbers in this assay, from the lowest: compounds 2 and 3 (each within the scatter of the next); then compound 4. At a limit, above all of these: compound 1.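

In this assay, an open chain at this aromatic carbon gave a measured number that differs from those of both larger ring-bearing groups: the (2-hydroxyethyl)amino group gave a 4.0-fold higher number from compound 3 to compound 4 (0.60 log units; beyond the scatter), and it gave a 4.0-fold higher number from compound 2 to compound 4 (0.60 log units; beyond the scatter). The same chain, against pyrrolidin-1-yl, gave an at least 2.3-fold lower number from compound 1 to compound 4 (0.36 log units; beyond the scatter), so the ringless group falls between the ring-bearing groups, and the presence of a ring does not by itself set the order, with compound 1 going against any such rule. Compound 1 alone remains at a limit, which is not a number: the limit of > 100000 nM in this assay, at which 1 of the 4 values shown sits.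

The compounds shown leave open whether the hydroxyl of the chain matters to the number, as neither an ethylamino nor a 2-methoxyethylamino group stands among them for comparison. They also leave open whether a longer chain, such as 3-hydroxypropylamino, or a chain ending in a dimethylamino group would bring the number closer to those of compound 2 and compound 3.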